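Selenium-Linked Quinoline Esters: Chloro for Methoxy on the Core

The source may report more compounds than this note shows. Statements on the series, on what has been measured and on what is new or still open speak of the compounds shown alone.

Measured compounds:
Compound 1, `CCOC(=O)c1cc([Se]c2ccc3cc(OC)ccc3c2)c2cc(OC)ccc2n1`, 30800 nM
Compound 2, `CCOC(=O)c1cc([Se]c2ccccc2)c2cc(Cl)ccc2n1`, 47100 nM
Compound 3, `CCOC(=O)c1cc([Se]c2ccccc2)c2cc(OC)ccc2n1`, 33000 nM

Of the compounds shown here, three have been measured in a functional assay on SK-MEL-147 cells (Homo sapiens) for cytotoxicity, read by MTT assay, with a stated time of 24 h; a lower number here means that less compound is needed, a higher number that more compound is needed for the effect. Compound 1 gives 30800 nM, compound 2 gives 47100 nM, and compound 3 gives 33000 nM. All three numbers lie within the scatter of one another, so none of them can be set apart.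

Compound 3 and compound 2 differ in one place: chloro in place of methoxy on an aromatic carbon. The step of a 1.4-fold higher number from compound 3 to compound 2 (0.15 log units; within the scatter) is within the scatter. The difference between the core of compound 1 and the core of compound 3 is not broken down here.

Compound 4, `CCOC(=O)c1cc([Se]c2ccc3cc(OC)ccc3c2)c2cc(Cl)ccc2n1`, is not yet measured. It differs from compound 1 in the same way: chloro in place of methoxy on an aromatic carbon. The two place descriptions agree word for word, so this is the same change as that from compound 3 to compound 2.

Compound 4 is therefore expected to follow the step seen before, with an estimated 1.4-fold higher number from compound 1 to compound 4 (0.14 log units; within the scatter), resting on compound 3 and compound 2 with a 1.4-fold higher number from compound 3 to compound 2 (0.15 log units; within the scatter). Compound 4 is estimated at 43000 nM, with an expected range from 20000 nM to 90000 nM.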

Compound 4, half-maximal effective concentration: 16200 nM
For compound 4 the middle estimate is 2.7-fold (0.42 log units) above the measured one; the measured number lies below the stated range.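

In this assay, chloro in place of methoxy on an aromatic carbon gives a 1.9-fold lower number from compound 1 to compound 4 (0.28 log units; within the scatter), and this step does not match the one seen on the other core: the same change on two cores in this assay, a 1.4-fold higher number (0.15 log units; within the scatter) from compound 3 to compound 2 and a 1.9-fold lower number (0.28 log units; within the scatter) from compound 1 to compound 4, 2.7-fold (0.43 log units) apart, beyond the scatter of two such steps

Carried from the core of compound 3 to the core of compound 1, the change therefore does not keep its size or its direction, so a step read on one of these cores cannot simply be transferred to the other in this series. This does not show why the two cores part, and it does not establish an effect of the change on either core alone, as each step by itself stays within the scatter and each rests on a single pair of compounds.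

The compounds shown leave open whether the same gap between the cores would appear with other groups at this place, such as fluoro, bromo or an amine. They also leave open whether it would persist if the ethyl ester gave way to a carboxylic acid or an amide, or if sulfur stood in place of selenium in the link.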